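The source may hold more compounds than are shown below. What is called first, only, known or untested is meant among the compounds shown, and "the series" means these compounds.

Compound 3 `CN(C)c1ccc(/C=C2\S/C(=N\c3nc(-c4ccc(Cl)cc4)cs3)NC2=O)cc1` is the stronger of the two compounds with a number in a functional assay on SW-620 cells (Homo sapiens) for cytotoxicity, read by MTT assay, with a stated time of 72 h; a lower number here means a stronger inhibitor, a higher number a weaker inhibitor. In this assay compound 3 gives 200 nM, whereas compound 1 `CN(C)c1ccc(/C=C2\S/C(=N\c3csc(-c4ccc(Cl)cc4)c3)NC2=O)cc1` gives 800 nM, a gap that lies beyond the usual scatter. Compound 2 `O=C1N/C(=N/c2csc(-c3ccc(Cl)cc3)c2)S/C1=C\c1ccc(O)cc1` was also prepared, but in this assay compound 2 has "not determined" (no result reported), so it contributes no number to the comparison.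

Compound 4 `O=C1N/C(=N/c2nc(-c3ccc(Cl)cc3)cs2)S/C1=C\c1ccc2ccccc2c1` keeps the core of compound 3 and alters only the aryl group on the exocyclic double bond: naphthalen-2-yl in place of 4-(dimethylamino)phenyl on a double-bonded chain carbon bound to a double-bonded ring carbon. Among the measured compounds shown here, there is no measured pair in this set that isolates such a change, and the one other variation at that position, the hydroxyphenyl of compound 2, lacks a result, so the direction of the step must be judged without a precedent. The loss of the dimethylamino group, which the two measured compounds share, leaves the naphthalen-2-yl analogue unanchored to any observed trend. A moderate weakening is expected for compound 4, with the step from compound 3 a 2.5-fold higher number from compound 3 to compound 4 (0.40 log units; beyond the scatter) likely to exceed the scatter only slightly, if at all. Compound 4 is therefore estimated at 500 nM, with a plausible range from 150 nM to 2500 nM.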

Compound 4, half-maximal inhibitory concentration: 20300 nM
The estimate for compound 4 lay 41-fold (1.61 log units) below the measured number; the whole stated range lies below it.
By their numbers in this assay, from the lowest: compound 3; then compound 1; then compound 4.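

In this assay, naphthalen-2-yl in place of 4-(dimethylamino)phenyl gives a 100-fold higher number from compound 3 to compound 4 (2.01 log units; beyond the scatter), so the aryl group on a double-bonded chain carbon bound to a double-bonded ring carbon has a large influence on the read-out, although the rest of the molecule is unchanged. Among the compounds shown here, no earlier measured pair spoke to this position, and this single step is the first sign of how much it matters. The entering group has two six-membered aromatic rings of carbon only and no nitrogen, but one step cannot separate these differences, and no measurement given here explains the size of the change.

The compounds shown leave open whether the dimethylamino group itself or the single phenyl ring is what the activity of compound 3 depends on, a question that a phenyl ring bearing a methoxy group or a morpholine at that place would help to settle. They also leave open whether the same exchange would weigh as heavily on the core of compound 1.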